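Aryl variation at the saturated ring carbon: working notes

The source may hold more compounds than are shown below. What is called first, only, known or untested is meant among the compounds shown, and "the series" means these compounds.

Compound 3 `N#CC1=C(N)N(c2ccc(S(N)(=O)=O)cc2)C2=C(CCCC2)C1c1ccc(Cl)c(Cl)c1` gives 1% in a functional assay on Ehrlich cells (Mus musculus) for cytotoxicity, read by trypan blue exclusion, with a stated time of 2 h, tested at 10 ug/mL; a higher number here means a stronger effect of the compound at the concentration tested, a lower number a weaker effect. Among the three measured numbers it stands second highest: compound 2 `N#CC1=C(N)N(c2ccc(S(N)(=O)=O)cc2)C2=C(CCCC2)C1c1cccc([N+](=O)[O-])c1` gives 0%, a number within the scatter of compound 3, while compound 1 `COc1ccccc1C1C(C#N)=C(N)N(c2ccc(S(N)(=O)=O)cc2)C2=C1CCCC2` gives 30%, higher beyond the scatter. The measured steps at this position are a number 30 percentage points lower from compound 1 to compound 2 (beyond the scatter), a number 29 percentage points lower from compound 1 to compound 3 (beyond the scatter) and a number 1 percentage points higher from compound 2 to compound 3 (within the scatter). Compound 4 `N#CC1=C(N)N(c2ccc(S(N)(=O)=O)cc2)C2=C(CCCC2)C1c1cccs1` brings (thiophen-2-yl in place of 3,4-dichlorophenyl on a saturated ring carbon). Going by the values given here, no measured step covers a thiophen-2-yl here; the steps show only that two aryl replacements at this carbon both fall well short of compound 1 and sit close to each other. The step expected from this change is a number 7 percentage points higher from compound 3 to compound 4 (within the scatter), small and probably within the scatter. For compound 4 the estimated value in this assay is 8%, within 0% to 30%.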

Compound 4, a percentage reported as activity, at one concentration (the size of the read-out at that concentration, not a potency): 0%
Estimate against measurement, compound 4: 8 percentage points above; the range from low to high includes it.
By their numbers in this assay, from the lowest: compounds 2, 4 and 3 (each within the scatter of the next); then compound 1.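

In this assay, the steps of a number 1 percentage points lower from compound 3 to compound 4 (within the scatter) and no change at the digits printed from compound 2 to compound 4 (within the scatter) show that thiophen-2-yl at this saturated ring carbon reads like 3,4-dichlorophenyl and 3-nitrophenyl, so a five-membered aromatic ring with a hetero atom also sits with the low group. Going by these compounds alone, the step of a number 30 percentage points lower from compound 1 to compound 4 (beyond the scatter) leaves 2-methoxyphenyl in compound 1 as the only aryl group of the four clearly apart from the others. Nothing at hand accounts for that separation.

Going by these compounds, whether the methoxy group itself or its place on the phenyl ring goes with the higher number of compound 1 stays open, as does the reading for a saturated amine such as piperidine at this carbon.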